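A few compounds are considered here, and "the series" means these few. Any claim that something is new, unique, unknown or untested is made for them only; others in the source may bear on it.

The measured compounds:
compound 1, `CCOC(=O)C(=O)CC(=O)/C=C/c1cn(Cc2ccc(OC)cc2)c2ccccc12`, > 40 uM
compound 2, `COc1ccc(Cn2cc(/C=C/C(=O)CC(=O)C(=O)O)c3ccccc32)cc1`, 10 uM
compound 3, `CCOC(=O)C(=O)CC(=O)/C=C/c1cc(C(=O)c2ccccc2)cn1Cc1ccccc1`, > 40 uM

In an assay on isolated protein for inhibition of DNA nucleotidylexotransferase (Homo sapiens), read by scintillation counting, with a stated time of 10 min (a lower number here means a stronger inhibitor, a higher number a weaker inhibitor), compound 1 reaches only a limit of the assay, > 40 uM. Compound 2 gives a number, 10 uM. The single difference between the two is hydrogen in place of ethyl on an oxygen next to a carbonyl group, and it brings an at least 4.0-fold lower number from compound 1 to compound 2 (0.60 log units; beyond the scatter). Compound 3 also stops at a limit of the assay, > 40 uM. Here (the limit of > 40 uM in this assay, at which 2 of the 3 values shown sit), so the exact size of any step that starts from compound 3 cannot be read off. The difference between the core of compound 1 and the core of compound 3 is not broken down here. Going by the values given here, compound 4, `O=C(/C=C/c1cc(C(=O)c2ccccc2)cn1Cc1ccccc1)CC(=O)C(=O)O`, differs from compound 3 by hydrogen in place of ethyl on an oxygen next to a carbonyl group, the same change as the one between compound 1 and compound 2, at a place described in the same words. For compound 4 the expected step is an at least 3.3-fold lower number from compound 3 to compound 4 (0.52 log units; beyond the scatter), which rests on an at least 4.0-fold lower number from compound 1 to compound 2 (0.60 log units; beyond the scatter). Compound 4 is therefore estimated to give 12 uM, with a likely range from 3 uM to 50 uM.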

Compound 4, concentration for 50% inhibition: 16 uM
For compound 4 the middle estimate is 1.3-fold (0.12 log units) below the measured one; low and high end bracket the measured number.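

Replacing ethyl with hydrogen on the ester oxygen, which turns ethoxycarbonyl into carboxy, gives a lower number on the second core as well in this assay, with an at least 2.5-fold lower number from compound 3 to compound 4 (0.39 log units; beyond the scatter). The change therefore carries over from the core of compound 1 to the core of compound 3 in its direction, and on both cores the step lies beyond the usual scatter: the same change on two cores in this assay, an at least 4.0-fold lower number (0.60 log units; beyond the scatter) from compound 1 to compound 2 and an at least 2.5-fold lower number (0.39 log units; beyond the scatter) from compound 3 to compound 4; the limit leaves it open whether they differ Compound 3 reaches only a limit of the assay, > 40 uM, so the full size of this step stays unknown, and two cores are too few to make a rule for the whole series: the limit of > 40 uM in this assay, at which 2 of the 4 values shown sit.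

The compounds shown leave open how the number would move if the carboxy group gave way to a methyl ester or to an amide. They also leave open whether the same step would appear on a core that carries another group, such as an amine or a longer chain.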